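Chloro in place of methyl on compound 1

The compounds below may be only part of what the source reports. "The series", "measured", "known", "first", "only" and "open" are said of these compounds alone.

In an ADME assay on the whole organism (Canis lupus familiaris) for metabolic stability, at a dose of 2 mg/kg by the intravenous route (on this read-out lower numbers stand for a shorter-lived compound and higher numbers for a longer-lived compound), compound 1 (`Cc1cc(C(F)(F)F)ccc1-c1cc2cnn([C@@H](CC(C)C)c3ccc(C(=O)NCCC(=O)O)cc3)c2cc1C`) gives 13.3 h and compound 2 (`Cc1cc(C(F)(F)F)ccc1-c1cc2cn([C@@H](CC(C)C)c3ccc(C(=O)NCCC(=O)O)cc3)nc2cc1C`) gives 21.7 h with the two values within the scatter of each other. For the measured compounds named here, compound 1 therefore stands level with the only other measured compound in this read-out. Compound 3 (`Cc1cc2c(cnn2[C@@H](CC(C)C)c2ccc(C(=O)NCCC(=O)O)cc2)cc1-c1ccc(C(F)(F)F)cc1Cl`) carries chloro in place of methyl on an aromatic carbon, the change from 2-methyl-4-(trifluoromethyl)phenyl to 2-chloro-4-(trifluoromethyl)phenyl (chloro in place of methyl on an aromatic carbon). Going by the values given here, no measured pair shows this change or any other single-place change, so the series gives no direct guide to its size. The estimate therefore stays close to compound 1 at 13.3 h and carries a wide range. The expected step of a 1.1-fold higher number from compound 1 to compound 3 (0.02 log units; within the scatter) is none beyond the scatter in either direction. For compound 3 the expected value is 14 h within an estimated range (7 h to 28 h).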

Compound 3, half-life: 16 h
The estimate for compound 3 lay 1.1-fold (0.06 log units) below the measured number; the range from low to high includes it.
By their numbers in this assay, from the lowest: compounds 1, 3 and 2 (each within the scatter of the next).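

For the compounds shown here, replacing the methyl of compound 1 with chloro, giving the 2-chloro-4-(trifluoromethyl)phenyl group of compound 3, provides the first single-place step: in this assay, a 1.2-fold higher number from compound 1 to compound 3 (0.08 log units; within the scatter). At this aromatic carbon, ortho to a large group, the half-life therefore does not separate chloro from methyl, so the position tolerates this exchange on the present read-out. No available measurement explains this outcome.

Going by these compounds, whether a different group at this position, such as methoxy, nitrile or a bare hydrogen, would produce a step beyond the scatter remains open. Also open, on these data alone, are whether the same exchange behaves alike on the core of compound 2 and whether replacing the trifluoromethyl group with a nitrile or a plain methyl would change the half-life.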